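Growing the Branched Ether Chain

A few compounds are considered here, and "the series" means these few. Any claim that something is new, unique, unknown or untested is made for them only; others in the source may bear on it.

In a functional assay on PC-3 cells (Homo sapiens) for antiproliferative activity, read by sulforhodamine B assay (on this read-out lower numbers stand for stronger inhibition of growth and higher numbers for weaker inhibition of growth), compound 1 `CCCCOc1cccc(O)c1C(=O)/C=C/c1ccc(O)cc1` gives > 30000 nM, which is a limit of the assay and not a number. For the measured compounds named here, compound 2 `CC(C)CCOc1cccc(O)c1C(=O)/C=C/c1ccc(O)cc1` gives 11500 nM, the only true number so far. Going by these compounds, putting methyl in place of hydrogen on a saturated chain carbon produced an at least 2.6-fold lower number from compound 1 to compound 2 (0.41 log units; beyond the scatter), a step whose full size stays open given (the limit of > 30000 nM in this assay, at which 1 of the 2 values shown sits). Compound 3 `CCC(CC)COc1cccc(O)c1C(=O)/C=C/c1ccc(O)cc1` differs from compound 2 in one place: pentan-3-yl in place of isobutyl on a saturated chain carbon bound to an oxygen on an aromatic ring. Going by the values given here, with that single earlier step as the only guide, a small further fall, possibly within the scatter, is expected: a 1.5-fold lower number from compound 2 to compound 3 (0.19 log units; within the scatter). For compound 3 the estimated value is 7500 nM, with a range of 2500 nM to 22000 nM.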

Compound 3, concentration for 50% growth inhibition: 3390 nM
Estimate against measurement, compound 3: 2.2-fold (0.34 log units) above; measured number inside the range.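

Replacing isobutyl with pentan-3-yl on this saturated chain carbon bound to an oxygen on an aromatic ring gives a second gain: a 3.4-fold lower number from compound 2 to compound 3 (0.53 log units; beyond the scatter). The fall in the number therefore does not stop at compound 2, and in this assay the larger 2-ethylbutoxy chain does better than isopentyloxy. Across the whole series the change reads an at least 8.8-fold lower number from compound 1 to compound 3 (0.94 log units; beyond the scatter), a step whose full size stays open: the limit of > 30000 nM in this assay, at which 1 of the 3 values shown sits. Going by these compounds, whether a still longer branched chain, a cyclohexyl ring or an amine on this chain would lower the number further remains open.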